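The source may hold more compounds than are shown below. What is called first, only, known or untested is meant among the compounds shown, and "the series" means these compounds.

Compound 1 `CCCCC(=O)NCCC(=O)c1cc(OC)ccc1N` gives 14.1% in an assay for inhibition of Nitric oxide synthase, inducible (Homo sapiens), read by scintillation counting, with a stated time of 30 min, tested at 1 mM; on this read-out higher numbers stand for more inhibition at the one concentration tested (going by the name of the read-out) and lower numbers for less inhibition.
Compound 2 `COc1ccc(N)c(C(=O)CCNC(=O)c2ccccc2)c1` gives 10.9% in this assay.
Compound 3 `Nc1ccc(Cl)cc1C(=O)CCNC(=O)c1ccccc1` gives 26.6% in this assay.

Among these three numbers compound 1 stands second highest. Its nearest neighbour is compound 2: the step of a number 3.2 percentage points lower from compound 1 to compound 2 (within the scatter) lies within the scatter, so the two cannot be told apart. Compound 3 sits furthest away, and its value is higher than that of compound 1 by more than the scatter.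

Compound 4 `CNC(=S)NCCC(=O)c1cc(OC)ccc1N` is the next compound. It differs from compound 1 in one place: a group of 4 heavy atoms (2 carbon, 1 nitrogen, 1 sulfur; no ring) in place of a group of 6 heavy atoms (5 carbon, 1 oxygen; no ring), on an amine nitrogen. Among the measured compounds shown here, only one measured step touches this same position, namely a number 3.2 percentage points lower from compound 1 to compound 2 (within the scatter), which swapped one group on the carbonyl carbon for another and changed almost nothing. The other step, a number 15.7 percentage points higher from compound 2 to compound 3 (beyond the scatter), alters the aromatic carbon instead and so says nothing about the amine nitrogen. On this thin basis no change beyond the scatter is expected in this assay, in either direction, though a group without a carbonyl has not been tried here, which widens the uncertainty. Compound 4 is therefore expected to give about 15%, with a range from 3% to 30%, an expected step of a number 0.9 percentage points higher from compound 1 to compound 4 (within the scatter).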

Compound 4, a percentage reported as inhibition, at one concentration (the size of the read-out at that concentration, not a potency): 78.2%
For compound 4 the middle estimate is 63.2 percentage points below the measured one, outside the stated range (above it).
By their numbers in this assay, from the lowest: compounds 2 and 1 (each within the scatter of the next); then compound 3; then compound 4.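

At the amine nitrogen, the group of 4 heavy atoms (2 carbon, 1 nitrogen, 1 sulfur) in place of butylcarbonyl gives a number 64.1 percentage points higher from compound 1 to compound 4 (beyond the scatter) in this assay, so this position can strongly change the read-out. The earlier change near this end of the molecule, a number 3.2 percentage points lower from compound 1 to compound 2 (within the scatter), only exchanged butyl for phenyl on a carbonyl carbon and left the carbonyl in place, whereas this step replaces the whole group, and the entering group holds sulfur and a hydrogen-bond donor that butylcarbonyl lacks. This single step cannot show which of these differences matters, or whether the smaller size of the group does, and no supporting evidence is available to explain the rise.

A urea, with oxygen where the sulfur stands, would separate the role of sulfur from that of the rest of the group, and an ethyl or longer chain in place of the methyl on its nitrogen would test how much room this end allows. Going by these compounds, it also remains open whether chloro in place of methoxy on the aromatic carbon, which gave a number 15.7 percentage points higher from compound 2 to compound 3 (beyond the scatter), would raise the number further in the core of compound 4.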